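Removing one benzyl group from the aniline nitrogen

The compounds below may be only part of what the source reports. "The series", "measured", "known", "first", "only" and "open" are said of these compounds alone.

Compound 1 `COc1ccc(N(Cc2ccccc2)CC(C)C)cc1` and compound 2 `COc1ccc(N(Cc2ccccc2)Cc2ccccc2)cc1` share one core and differ only in one branch attached to the nitrogen. In a functional assay on L929 cells (Mus musculus) for inhibition, read by MTT assay, with a stated time of 5 days (on this read-out lower numbers stand for stronger inhibition and higher numbers for weaker inhibition), compound 1 gives 10 ug/mL, and compound 2 gives 12 ug/mL. Among the compounds with values here, the single measured step, a 1.2-fold higher number from compound 1 to compound 2 (0.08 log units; within the scatter), shows that exchanging the branch produced no change that can be trusted. Compound 2 has the higher of the two numbers, yet its distance to compound 1 lies within the scatter, so the two cannot be told apart.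

Compound 3 `COc1ccc(NCc2ccccc2)cc1` is not yet measured. It arises from compound 2 by hydrogen in place of benzyl on a nitrogen on an aromatic ring, so one of the two groups on the nitrogen is removed and only a hydrogen remains there. Within the data shown here, no measured step touches this kind of change; the only available step altered a branch while keeping the nitrogen fully substituted, and it stayed within the scatter. With nothing pointing in either direction, the expectation for this assay is no step beyond the scatter, with wide uncertainty. Compound 3 is therefore estimated at 12 ug/mL, with a range from 5 ug/mL to 30 ug/mL. For compound 3 the expected step of no change at the digits printed from compound 2 to compound 3 (within the scatter) is thus small.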

Compound 3, half-maximal inhibitory concentration: 30 ug/mL
Compound 3: middle estimate off by 2.5-fold (0.40 log units), on the low side; low and high end bracket the measured number.
By their numbers in this assay, from the lowest: compounds 1 and 2 (each within the scatter of the next); then compound 3.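

In this assay, within the data shown here, the nitrogen on an aromatic ring had so far been seen only with two carbon groups on it, and exchanging one of these for another gave no change that could be trusted. Among these compounds, removing a group and leaving hydrogen is the first change here to go beyond the scatter, with a 2.5-fold higher number from compound 2 to compound 3 (0.40 log units; beyond the scatter) when benzyl leaves and a 3.0-fold higher number from compound 1 to compound 3 (0.48 log units; beyond the scatter) when isobutyl leaves, and since a higher number stands for weaker inhibition, compound 3 is the weakest of the three, though only modestly so. Among these three compounds, then, having a second carbon group on this nitrogen counts for more than whether that group is benzyl or isobutyl.

No separate measurement is available to explain this modest loss. As far as these compounds go, it remains open whether a small group such as methyl, or an acetyl group, on this nitrogen would give a number close to those of compound 1 and compound 2 or one close to that of compound 3.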